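Fluoro in Place of Methoxy on a Triazole Antiproliferative

The source may hold more compounds than are shown below. What is called first, only, known or untested is meant among the compounds shown, and "the series" means these compounds.

Among the measured compounds shown here, compound 1 `COc1ccc(-c2ncnn2-c2cc(OC)c(OC)c(OC)c2)cc1` is the one member of this small set with a numerical reading in a functional assay on HL-60 cells (Homo sapiens) for antiproliferative activity, read by MTT assay, with a stated time of 72 h (a higher number here means a weaker inhibitor, a lower number a stronger inhibitor), where compound 1 gives 120 nM. Compound 2 `COc1cc(-c2ncnn2-c2ccc(N)cc2)cc(OC)c1OC` yields only a limit in this assay, as compound 2 gives > 10000 nM. That reading for compound 2 is a limit of the assay and not a number (the limit of > 10000 nM in this assay, at which 1 of the 2 values shown sits). For the measured compounds named here, no pair of measured compounds differing in a single place is available, so compound 1 stands as the single fixed point from which any forecast must start.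

Compound 3 `COc1cc(-n2ncnc2-c2ccc(F)cc2)cc(OC)c1OC` differs from compound 1 in one respect: fluoro in place of methoxy on an aromatic carbon. With no measured step of this kind in hand, the expectation rests on compound 1 alone at 120 nM. The step of a 13-fold higher number from compound 1 to compound 3 (1.10 log units; beyond the scatter) is expected to run toward weaker inhibition, beyond the usual scatter, rather than to leave the reading unchanged. On that basis compound 3 is estimated at 1500 nM in this assay, with a range expected from 300 nM to 8000 nM.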

Compound 3, half-maximal inhibitory concentration: > 10000 nM
Compound 3: a limit, no number; the forecaster's own chance of this, stated with the estimate: 20%; middle value at least 6.6-fold (0.82 log units) away from the limit.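

Among the compounds shown here, the change from 4-methoxyphenyl to 4-fluorophenyl, the only step between compounds differing in one place, is far from neutral in this assay: it gives an at least 83-fold higher number from compound 1 to compound 3 (1.92 log units; beyond the scatter) and so shows that this place, para to a large group, does not tolerate the exchange without a large loss. The reading of compound 3 at > 10000 nM is a limit of the assay and not a number, and it joins a second reading at that same limit: the limit of > 10000 nM in this assay, at which 2 of the 3 values shown sit. Compound 1 gives 120 nM in this assay with methoxy at this place, which marks the group as the one measurable reading here, although nothing shown says why the exchange costs so much.

The compounds shown do not separate the loss of methoxy from the arrival of fluoro, and a hydroxy, methyl, chloro or ethoxy group at this place would be needed to tell which of the two counts. As far as these compounds go, how far the true reading of compound 3 lies from its limit also stays open, as does whether the same exchange would behave alike on another ring of the core of compound 1.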